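This account rests on a few compounds, and the source may have more. Where it says the series, first, only, none or still open, it means among the compounds named here.

Measured so far:
Compound 1 `Nc1cc(-c2ccc(Cl)cc2)nc2cc(-c3ccccc3)nn12` — 51.2%
Compound 2 `Nc1cc(-c2ccc(Br)cc2)nc2cc(-c3ccc(Cl)cc3)nn12` — 76.2%

Both compounds were tested in a functional assay on the whole organism (strain Wistar) for inhibition, with Rattus norvegicus as the target, read by paw edema, with stated times of 30 min and 4 h, at a dose of 50 mg/kg by the oral route; on this read-out higher numbers stand for more inhibition at the one dose given (going by the name of the read-out) and lower numbers for less inhibition. Compound 2 gives 76.2% and stands highest of the two numbers; compound 1 gives 51.2%, a number lower by more than the usual scatter. Going by the values given here, no single-point step between the two measured compounds is available, as they differ in more than one place.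

Compound 3 `Cc1ccc(-c2cc3nc(-c4ccc(Br)cc4)cc(N)n3n2)cc1` is not yet measured. It differs from compound 2 in one place: methyl in place of chloro on an aromatic carbon. Among the compounds with values here, the exchange of one halogen for a methyl on the outer ring has no measured counterpart, so the direction of the step is open. A change of this size is expected to stay within or just beyond the scatter, with no strong shift in either direction.

The step of a number 6.2 percentage points lower from compound 2 to compound 3 (within the scatter) is the estimated change. Compound 3 is thus expected to give about 70%, in the range 55% to 85%.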

Compound 3, a percentage reported as inhibition, in the whole organism at one dose (the size of the read-out at that dose, not a potency): 66.7%
Compound 3: middle estimate off by 3.3 percentage points, on the high side; the range from low to high includes it.
By their numbers in this assay, from the lowest: compound 1; then compounds 3 and 2 (each within the scatter of the next).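

In this assay, going by these compounds alone, the exchange of 4-chlorophenyl for 4-methylphenyl gives the only one-place step so far, a number 9.5 percentage points lower from compound 2 to compound 3 (within the scatter). At this position, on a six-membered aromatic ring of carbon only and para to a large group, chloro is therefore not needed to keep the inhibition at the one dose given, as methyl in its place gives a number that cannot be told from that of chloro. This holds for this one pair only, and no measurement available here offers a reason for the step.

Still open, going by these compounds, is how this position responds to groups of another kind, such as a carboxylic acid, a morpholine or a longer chain like butyl. Open too, on these data alone, is whether the same exchange reads alike with other groups elsewhere on the shared core.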